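The compounds below may be only part of what the source reports. "The series", "measured", "known", "first", "only" and "open" are said of these compounds alone.

Working notes on the series.

Compound 1, `N#Cc1ccccc1-c1nc2cccnc2o1`, is tested in a functional assay on the whole organism for inhibition, with Rattus norvegicus as the target, at a dose of 30 mg/kg (a lower number here means less inhibition, a higher number more inhibition at the dose given (going by the name of the read-out)), where compound 1 gives 61%. For the measured compounds named here, the only other compound with a number so far is compound 2, `COc1ccc(Br)c(-c2nc3ncccc3o2)c1`, and in this assay compound 2 gives 8%. Compound 1 therefore holds the higher of the two numbers, and the gap to compound 2 is well beyond the usual scatter of the measurement; compound 2 differs from compound 1 in more than one place, so the two values say nothing about any single change.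

Compound 3, `Cc1ccccc1-c1nc2cccnc2o1`, has not yet been measured in this assay. It differs from compound 1 in one place: methyl in place of cyano on an aromatic carbon. Going by the values given here, no measured pair isolates this change, so the expectation rests on compound 1 alone and on the fact that a group is lost without any added acceptor. A downward step is expected, and the estimated step from compound 1 to compound 3 in this assay is a number 26 percentage points lower from compound 1 to compound 3 (beyond the scatter). For compound 3 the estimate in this assay is 35%, with a range from 10% to 60%.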

Compound 3, a percentage reported as inhibition, in the whole organism at one dose (the size of the read-out at that dose, not a potency): 3%
Compound 3: middle estimate off by 32 percentage points, on the high side, and the stated range ends above it.
By their numbers in this assay, from the lowest: compounds 3 and 2 (each within the scatter of the next); then compound 1.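

In this assay, for the compounds shown here, the exchange of cyano for methyl on an aromatic carbon of the six-membered aromatic ring of carbon only, ortho to a group of 9 heavy atoms, gives a number 58 percentage points lower from compound 1 to compound 3 (beyond the scatter) and is the first step that isolates a single change. It shows that the read-out is sensitive to the group at this position: on the same core, compound 1 with cyano gives 61% while compound 3 with methyl gives 3% in this assay at the one dose tested. The compounds shown offer no evidence on why this exchange has so large an effect.

The compounds shown compare only cyano and methyl at this position, so they leave open whether the higher number is particular to cyano or is shared by other groups, such as a carboxamide, a primary amine, a carboxylic acid or chlorine. Because the read-out is a single-dose percentage, they also leave open how the two compounds would compare across a range of doses.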